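Compound 4 in this assay: 1H-benzimidazol-2-yl for 4-chlorophenyl

The compounds below may be only part of what the source reports. "The series", "measured", "known", "first", "only" and "open" are said of these compounds alone.

The series shares one core and varies the group on a saturated chain carbon bound to a sulfur. In an ADME assay on GES1 cells (Homo sapiens) for inhibition, read by MTT assay, with a stated time of 72 h (a higher number here means a weaker inhibitor, a lower number a stronger inhibitor), compound 1 `Cc1cc(Nc2cc(-c3ccccc3)[nH]n2)n2nc(SCc3ccc([N+](=O)[O-])cc3)nc2n1` gives 43600 nM. Compound 2 `Cc1cc(Nc2cc(-c3ccccc3)[nH]n2)n2nc(SCc3csc4ccccc34)nc2n1` gives 29200 nM, and compound 3 `Cc1cc(Nc2cc(-c3ccccc3)[nH]n2)n2nc(SCc3ccc(Cl)cc3)nc2n1` gives 31800 nM. The three numbers lie close together: a 1.5-fold lower number from compound 1 to compound 2 (0.17 log units; within the scatter), a 1.4-fold lower number from compound 1 to compound 3 (0.14 log units; within the scatter) and a 1.1-fold higher number from compound 2 to compound 3 (0.04 log units; within the scatter). Compound 3 thus holds the second highest of the three numbers, nearest to compound 2 and furthest from compound 1, both within the scatter.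

Compound 4 `Cc1cc(Nc2cc(-c3ccccc3)[nH]n2)n2nc(SCc3nc4ccccc4[nH]3)nc2n1` is not yet measured in this assay. It differs from compound 3 as follows: 1H-benzimidazol-2-yl in place of 4-chlorophenyl on a saturated chain carbon bound to a sulfur. Among the measured compounds shown here, two measured steps bear on this change, since both vary the group on the same sulfur-bound carbon: a 1.5-fold lower number from compound 1 to compound 2 (0.17 log units; within the scatter), where a bicyclic group replaces a six-membered ring, and a 1.1-fold higher number from compound 2 to compound 3 (0.04 log units; within the scatter), the reverse kind of swap. Neither step left the scatter, and the three groups tried so far all give much the same number. For the measured compounds named here, the entering group brings a hydrogen-bond donor and acceptor with no precedent among the measured compounds, so the range is kept wide. For compound 4 the expected step is a 1.0-fold higher number from compound 3 to compound 4 (0.00 log units; within the scatter), none beyond the scatter, with an estimate of 32000 nM and a range from 12000 nM to 85000 nM.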

Compound 4, half-maximal inhibitory concentration: 27800 nM
Estimate against measurement, compound 4: 1.2-fold (0.06 log units) above; the range from low to high includes it.
By their numbers in this assay, from the lowest: compounds 4, 2, 3 and 1 (each within the scatter of the next).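

In this assay the 1H-benzimidazol-2-yl group stays within the scatter of all three groups tried earlier (a 1.1-fold lower number from compound 3 to compound 4 (0.06 log units; within the scatter); a 1.1-fold lower number from compound 2 to compound 4 (0.02 log units; within the scatter); a 1.6-fold lower number from compound 1 to compound 4 (0.20 log units; within the scatter)). The earlier compounds shown here covered only 4-nitrophenyl, 4-chlorophenyl and 1-benzothiophen-3-yl, whereas this change replaces a six-membered aromatic ring of carbon only with a fused pair that includes a five-membered aromatic ring with 2 hetero atoms and adds a hydrogen-bond donor and acceptor to the count for 4-chlorophenyl, and even so the read-out does not separate the four compounds. No measurement available here gives a reason for this lack of separation.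

On these data alone, all four groups on the saturated chain carbon bound to a sulfur are aromatic, so it remains open whether a piperidine, a carboxylic acid or a plain alkyl chain there would stay within the same scatter. Also open is whether replacing the phenyl on the pyrazole-bearing part of the shared core, which is constant in all four compounds, would move the number further than any change shown at this position.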